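The compounds below may be only part of what the source reports. "The series", "measured", "known", "first", "only" and "open" are said of these compounds alone.

Measured so far:
- compound 1, `COc1cccc(N2CCN(c3ccc(C(=O)/C=C/c4ccccc4)cc3)CC2)c1`: 16%
- compound 2, `COc1cccc(N2CCN(c3ccc(C(=O)/C=C/c4ccc(Cl)cc4)cc3)CC2)c1`: 2.28%

Within the data shown here, in a functional assay on the whole organism (strain Kunming) for inhibition, with Mus musculus as the target, with a stated time of 1 h, at a dose of 40 mg/kg by the oral route (on this read-out higher numbers stand for more inhibition at the one dose given (going by the name of the read-out) and lower numbers for less inhibition), compound 1 gives 16%, the higher of the two numbers recorded; compound 2 gives 2.28%, and the only recorded step is a number 13.7 percentage points lower from compound 1 to compound 2 (beyond the scatter). That step concerns the aromatic ring at the far end of the shared core and leaves the amine nitrogen in a ring untouched.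

Compound 3, `O=C(/C=C/c1ccccc1)c1ccc(N2CCN(S(=O)(=O)c3ccc(Br)cc3)CC2)cc1`, is not yet measured in this assay. It differs from compound 1 as follows: (4-bromophenyl)sulfonyl in place of 3-methoxyphenyl on an amine nitrogen in a ring. Among the measured compounds shown here, no measured step alters the group on that ring nitrogen, so nothing bears directly on this change, and the size and direction of the step cannot be read from the numbers in hand. For the measured compounds named here, the one step available, a number 13.7 percentage points lower from compound 1 to compound 2 (beyond the scatter), came from a different part of the molecule and is not transferable.

Going by the values given here, with no relevant precedent, the estimate for compound 3 is taken close to the starting point, a step of a number 2 percentage points lower from compound 1 to compound 3 (within the scatter), with a wide band to reflect the absence of a guiding step. Compound 3 is therefore expected to give about 14%, between 0% and 35%.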

Compound 3, a percentage reported as inhibition, in the whole organism at one dose (the size of the read-out at that dose, not a potency): 47.4%
Estimate against measurement, compound 3: 33.4 percentage points below; measured number outside the range, above it.
By their numbers in this assay, from the lowest: compound 2; then compound 1; then compound 3.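

In this assay, the group on the amine nitrogen in a ring turns out to be a position where a single change moves the read-out, and the move is upward: with (4-bromophenyl)sulfonyl in place of 3-methoxyphenyl, the series shows a number 31.4 percentage points higher from compound 1 to compound 3 (beyond the scatter). Among these compounds, this is the first step seen at this position, and it runs opposite in direction to the only earlier step, the chloro change, which gave a number 13.7 percentage points lower from compound 1 to compound 2 (beyond the scatter). The exchange alters several features at once, since the sulfonyl link and the bromine enter as the methoxy leaves, and the compounds shown offer no explanation for the rise, nor any way of dividing it among these features.

From the compounds shown here alone, it remains open whether the step belongs to the sulfonyl link or to the bromine, a question that a plain phenylsulfonyl, a methylsulfonyl or a 4-bromobenzoyl group on the same nitrogen would help to settle. Going by these compounds, it is equally open whether the lower number seen with chloro on the far aromatic ring would recur on a compound carrying the (4-bromophenyl)sulfonyl group.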